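This account rests on a few compounds, and the source may have more. Where it says the series, first, only, none or still open, it means among the compounds named here.

Measured compounds and their values:
compound 1, `COc1ccc(C2SCC(=O)N2CCN2CCCCC2)cc1`, gives 11% in an ADME assay on Vero cells (Chlorocebus sabaeus) for cytotoxicity, read by neutral red uptake, tested at 3150 ug/mL; a lower number here means a stronger effect, a higher number a weaker effect of the compound at the concentration tested;
compound 2, `O=C1CSC(c2ccc(F)cc2)N1CCN1CCCCC1`, gives 11% in this assay;
compound 3, `O=C1CSC(c2cccc(F)c2)N1CCN1CCCCC1`, gives 13% in this assay.

Compound 3 has the highest of the three numbers, but its neighbours sit close: a number 2 percentage points higher from compound 2 to compound 3 (within the scatter), where the change is 3-fluorophenyl in place of 4-fluorophenyl on a saturated ring carbon. Within the same core, no change at the digits printed from compound 2 to compound 1 (within the scatter), the change being (methoxy in place of fluoro on an aromatic carbon).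

Compound 4, `COc1cccc(C2SCC(=O)N2CCN2CCCCC2)c1`, is not yet measured in this assay. It differs from compound 3 by methoxy in place of fluoro on an aromatic carbon. This is the same kind of change as from compound 2 to compound 1, though the place is not identical: there the group sits para to a large group, here meta to a large group. Because no change at the digits printed from compound 2 to compound 1 (within the scatter), the author expects no change at the digits printed from compound 3 to compound 4 (within the scatter), so compound 4 is estimated at 13%, between 5% and 22%.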

Compound 4, a percentage reported as activity, at one concentration (the size of the read-out at that concentration, not a potency): 6%
Beside the measured number, compound 4's estimate is 7 percentage points above it, and the stated range covers the measured number.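

Moving from the one fluorophenyl compound to the other, methoxy in place of fluoro gives a number 7 percentage points lower from compound 3 to compound 4 (within the scatter). Set beside the earlier case in this assay, the two steps do not separate: the same change on two cores in this assay, no change at the digits printed (within the scatter) from compound 2 to compound 1 and a number 7 percentage points lower (within the scatter) from compound 3 to compound 4, 7 percentage points apart, within the scatter of two such steps. The change therefore carries across these two cores with no difference that can be told from the scatter, but two pairs, each with its step within the scatter, do not show that it would behave the same on other cores or at other places on the aromatic ring.

The compounds shown leave open how a nitrile, an amine or a carboxylic acid on that aromatic carbon would compare with fluoro and methoxy in this assay. They also leave open whether a longer alkoxy chain in place of methoxy would read the same.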